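The source may hold more compounds than are shown below. What is called first, only, known or untested is meant among the compounds shown, and "the series" means these compounds.

Within the data shown here, compound 2, with structure `O=C(NCc1cn(Cc2ccc([N+](=O)[O-])cc2)nn1)c1ccc([N+](=O)[O-])o1`, is one of two compounds measured in an ADME assay on MRC5 cells (Homo sapiens) for cytotoxicity (a lower number here means a stronger inhibitor, a higher number a weaker inhibitor), where compound 2 gives 213000 nM. Among the measured compounds shown here, the only other measured compound, compound 1, with structure `COc1ccc(Cn2cc(CNC(=O)c3ccc([N+](=O)[O-])o3)nn2)cc1O`, gives 189000 nM in this assay. The two values lie within the scatter of each other, so neither compound can be set apart from the other on this read-out.

Compound 3, with structure `COc1cc(Cn2cc(CNC(=O)c3ccc([N+](=O)[O-])o3)nn2)ccc1O`, is not yet measured. Its change from compound 2 is 4-hydroxy-3-methoxyphenyl in place of 4-nitrophenyl on a saturated chain carbon bound to an aromatic nitrogen. For the measured compounds named here, the one measured step that bears on this is a 1.1-fold higher number from compound 1 to compound 2 (0.05 log units; within the scatter), in which a hydroxy-methoxyphenyl group gave way to the nitrophenyl group at the same position and the number hardly moved. Going by the values given here, compound 3 carries the hydroxy and methoxy groups in the reversed arrangement to compound 1, but the only evidence available shows this kind of swap on this position leaving this assay almost untouched. The step of a 1.1-fold lower number from compound 2 to compound 3 (0.04 log units; within the scatter) is therefore expected to stay within the scatter, with no direction that can be read from the data. Compound 3 is estimated to give 195000 nM in this assay, within a range of 100000 nM to 400000 nM.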

Compound 3, half-maximal inhibitory concentration: 182000 nM
The estimate for compound 3 lay 1.1-fold (0.03 log units) above the measured number; the range from low to high includes it.
By their numbers in this assay, from the lowest: compounds 3, 1 and 2 (each within the scatter of the next).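

In this assay, exchanging 4-nitrophenyl for 4-hydroxy-3-methoxyphenyl gives a 1.2-fold lower number from compound 2 to compound 3 (0.07 log units; within the scatter), so a second comparison of these aryl groups also fails to separate the compounds. Among these compounds, the new pair adds a test that the earlier compounds did not offer: exchanging 3-hydroxy-4-methoxyphenyl for 4-hydroxy-3-methoxyphenyl gives a 1.0-fold lower number from compound 1 to compound 3 (0.02 log units; within the scatter), showing that this change in the arrangement of the hydroxy and methoxy groups has no readable effect on the number. Across these three compounds, then, the three substituted phenyl groups at this place cannot be told apart on this read-out. Nothing available bears on the reason for this result.

From the compounds shown here alone, it remains open whether an amine or a carboxylic acid on the phenyl ring, or a longer chain at this place, would move the number beyond the scatter. All three compounds also share the same core, so they leave open how a change elsewhere in the structure would act on this read-out.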